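This account rests on a few compounds, and the source may have more. Where it says the series, first, only, none or still open, it means among the compounds named here.

Compound 1 `Cc1nc(C#Cc2ccccc2F)cs1` gives 140 nM in a functional assay on CHO cells for agonist activity at metabotropic glutamate receptor 5 (Homo sapiens), read by inositol phosphate accumulation; a higher number here means a weaker inhibitor, a lower number a stronger inhibitor. Compound 2 `COc1ccccc1C#Cc1csc(C)n1` differs from it by methoxy in place of fluoro on an aromatic carbon, and in this assay compound 2 gives 36.3 nM, so that the step is a 3.9-fold lower number from compound 1 to compound 2 (0.59 log units; beyond the scatter). Compound 3 `Cc1nc(C#Cc2cncc(-c3ccc(F)cc3)c2)cs1` is built on a different core; how its core differs from that of compound 1 is not broken down here. In this assay compound 3 gives 162 nM, a number within the usual scatter of that of compound 1 and beyond the scatter from that of compound 2. Compound 4 `COc1ccc(-c2cncc(C#Cc3csc(C)n3)c2)cc1` arises from compound 3 by methoxy in place of fluoro on an aromatic carbon, the same kind of change as from compound 1 to compound 2, but not the same change: in compound 2 the methoxy stands ortho to a group of 8 heavy atoms, whereas in compound 4 it stands para to a large group. Since the step of a 3.9-fold lower number from compound 1 to compound 2 (0.59 log units; beyond the scatter) came from a change at a different place, a smaller step is expected here, a 1.8-fold lower number from compound 3 to compound 4 (0.26 log units; within the scatter). Compound 4 is expected to give about 90 nM, most likely between 30 nM and 300 nM.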

Compound 4, half-maximal inhibitory concentration: 225 nM
Estimate against measurement, compound 4: 2.5-fold (0.40 log units) below; low and high end bracket the measured number.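

In this assay, methoxy in place of fluoro does not bring a step of the same size on the two cores: the same change on two cores in this assay, a 3.9-fold lower number (0.59 log units; beyond the scatter) from compound 1 to compound 2 and a 1.4-fold higher number (0.14 log units; within the scatter) from compound 3 to compound 4, 5.4-fold (0.73 log units) apart, beyond the scatter of two such steps

On the second core the change gives a 1.4-fold higher number from compound 3 to compound 4 (0.14 log units; within the scatter), so the clear drop in the number seen on the first core does not reappear here, and a result for this change on one core cannot simply be carried over to the other. The two pairs also differ in where the change sits, with the methoxy of compound 4 para to a large group, so these data cannot separate the effect of the core from the effect of the place, and two pairs make no general rule for the series.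

Still open, as far as these compounds go, is how other groups would behave at the place para to a large group, such as a chlorine, a hydroxyl or an amine. Also open, from the compounds shown here alone, is whether this same change on a third core would follow the first pair or the second.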